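The compounds below may be only part of what the source reports. "The series", "measured", "known", "first", "only" and "open" are said of these compounds alone.

- compound 1 `COc1cc(CN(CC(C)C)C(CC(=O)O)c2ccc(Cl)cc2)ccc1OCCN1C(=O)CCC1=O` gives 3000000 nM
- compound 2 `COc1cc(CN(CC(C)C)C(CC(=O)O)c2ccc(Cl)c(Cl)c2)ccc1OCCN1C(=O)CCC1=O` gives 3000000 nM
- compound 3 `COc1cc(CN(CC(C)C)C(CC(=O)O)c2ccc(Cl)cc2Cl)ccc1OCCN1C(=O)CCC1=O` gives 3000000 nM

In a physicochemical assay for solubility, at pH 1.1 (a lower number here means a less soluble compound, a higher number a more soluble compound), compound 3 stands level with compound 1 and compound 2 at the digits shown. Compound 4 `COc1cc(CN(CC(C)C)C(CC(=O)O)c2ccc(Cl)c(F)c2)ccc1OCCN1C(=O)CCC1=O` carries 4-chloro-3-fluorophenyl in place of 2,4-dichlorophenyl on a saturated chain carbon bound to an amine nitrogen and a saturated chain carbon. Three measured steps alter this same phenyl group: no change at the digits printed from compound 1 to compound 2 (within the scatter) and no change at the digits printed from compound 1 to compound 3 (within the scatter) and also no change at the digits printed from compound 2 to compound 3 (within the scatter) all stay within the scatter. From the compounds shown here alone, none of them puts fluoro on the ring, so that swap remains untested. No step beyond the scatter is therefore expected in this assay in either direction, and the estimate means no change at the digits printed from compound 3 to compound 4 (within the scatter) for this change. Compound 4 is estimated at 3000000 nM with 1500000 nM to 3500000 nM as the expected range.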

Compound 4, solubility: 3000000 nM
Beside the measured number, compound 4's estimate shows no gap at the digits printed; the range from low to high includes it.
By their numbers in this assay, from the lowest: compounds 1, 2, 3 and 4 (each within the scatter of the next).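

Once fluoro is on this phenyl group, this assay gives no change at the digits printed from compound 3 to compound 4 (within the scatter) and no change at the digits printed from compound 2 to compound 4 (within the scatter) and also no change at the digits printed from compound 1 to compound 4 (within the scatter) for this series. Fluoro therefore joins chloro as a ring substituent that leaves the reading level, whether it replaces hydrogen or chloro. Nothing available explains this level reading.

Still open, from the compounds shown here alone, is whether a nitrile or an amine on this phenyl group would also leave the reading level. Going by these compounds, replacing the chloro of the 4-chloro-3-fluorophenyl group with a methyl is equally open.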